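A few compounds are considered here, and "the series" means these few. Any claim that something is new, unique, unknown or untested is made for them only; others in the source may bear on it.

Measured compounds:
- compound 1 `Cc1cccc(NC(=O)c2ccc(/N=N\c3c[nH]c4ccccc34)cc2)c1C`: 51600 nM
- compound 2 `O=C(Nc1ccccc1[N+](=O)[O-])c1ccc(/N=N\c2c[nH]c3ccccc23)cc1`: 77900 nM
- compound 3 `Cc1ccccc1NC(=O)c1ccc(/N=N\c2c[nH]c3ccccc23)cc1`: "not active" (no number reported)

In a functional assay on P388 cells (Mus musculus) for inhibition, read by MTT assay, with a stated time of 72 h (on this read-out higher numbers stand for weaker inhibition and lower numbers for stronger inhibition), compound 1 gives 51600 nM and compound 2 gives 77900 nM. Compound 3 stands apart: in this assay compound 3 gives "not active" (no number reported), so no single number describes it, and it can only be placed as weaker than, or at best comparable to, the two numbered compounds. The step from compound 3 to compound 4 `O=C(Nc1ccc([N+](=O)[O-])cc1)c1ccc(/N=N\c2c[nH]c3ccccc23)cc1` is 4-nitrophenyl in place of 2-methylphenyl on an amide-type nitrogen. For the measured compounds named here, the one measured step that bears on it is a 1.5-fold higher number from compound 1 to compound 2 (0.18 log units; within the scatter), where a nitrophenyl likewise entered in place of a methylated phenyl on the same amide-type nitrogen, and the change stayed within the scatter. Going by the values given here, nothing among the measured compounds therefore points to a step beyond the scatter in this assay in either direction, and the expectation for compound 4 is a weak value near that of compound 2. Compound 4 is estimated at 70000 nM, with a range from 20000 nM to 250000 nM.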

Compound 4, half-maximal inhibitory concentration: 11200 nM
Compound 4: the middle estimate sits 6.3-fold (0.80 log units) above what was measured; the measured number lies below the stated range.
By their numbers in this assay, from the lowest: compound 4; then compounds 1 and 2 (each within the scatter of the next).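

In this assay, 4-nitrophenyl in place of 2-nitrophenyl on the amide-type nitrogen gives a 7.0-fold lower number from compound 2 to compound 4 (0.84 log units; beyond the scatter), so the two nitrophenyl groups are not interchangeable at this position, something the earlier step within the scatter could not show. Against the methylated phenyl of the measured pair, 4-nitrophenyl in place of 2,3-dimethylphenyl gives a 4.6-fold lower number from compound 1 to compound 4 (0.66 log units; beyond the scatter), so only this nitrophenyl, and not nitrophenyl as such, separates from compound 1. No measurement shown here accounts for these steps.

The step from compound 3 cannot be read, as compound 3 has no number. Whether the lower number depends on the nitro group itself remains open, since no phenyl carrying an amine or a carboxylic acid in its place appears among these compounds.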